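Naphthalen-2-yl for 4-methoxyphenyl on the carbonyl

The compounds below may be only part of what the source reports. "The series", "measured", "known", "first", "only" and "open" are said of these compounds alone.

Measured so far in a functional assay on HCT-116 cells (Homo sapiens) for inhibition, read by MTT assay, with a stated time of 48 h (on this read-out lower numbers stand for stronger inhibition and higher numbers for weaker inhibition), each value a limit and not a number:
- compound 1 `COc1cc(-c2nnc(SCc3ccc(C)cc3)n2-c2ccc(N(C)C)cc2)cc(OC)c1OC` gives > 60000 nM (limit)
- compound 2 `COc1cc(-c2nnc(SCc3ccc(F)cc3)n2-c2ccc(N(C)C)cc2)cc(OC)c1OC` gives > 60000 nM (limit)
- compound 3 `COc1ccc(C(=O)CSc2nnc(-c3cc(OC)c(OC)c(OC)c3)n2-c2ccc(N(C)C)cc2)cc1` gives > 60000 nM (limit)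

Compound 3 stands at > 60000 nM as a limit, not a number. The whole set shows the limit of > 60000 nM in this assay, at which 3 of the 3 values shown sit, with no exception. Compound 4 `COc1cc(-c2nnc(SCC(=O)c3ccc4ccccc4c3)n2-c2ccc(N(C)C)cc2)cc(OC)c1OC` differs from compound 3 by naphthalen-2-yl in place of 4-methoxyphenyl on a carbonyl carbon with naphthalen-2-yl in place of 4-methoxyphenyl on a carbonyl carbon. The nearest steps are a step that the two limits leave unreadable from compound 1 to compound 3 and a step that the two limits leave unreadable from compound 2 to compound 3 and neither gives a size. No step beyond the scatter is therefore expected in this assay on these data alone. The expected step is a number no higher from compound 3 to compound 4 (the limit leaves the size open) and its direction cannot be read from the data. For compound 4 the estimate is 60000 nM within a range of 8000 nM to 60000 nM and is kept wide towards lower numbers.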

Compound 4, half-maximal inhibitory concentration: 54500 nM
Beside the measured number, compound 4's estimate is 1.1-fold (0.04 log units) above it; the measured number falls inside the stated range.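

In this assay, compound 4 is the only compound shown that reads as a number and not a limit, so naphthalen-2-yl on the carbonyl carbon gives the only readable value in the set. The readings are an at least 1.1-fold lower number from compound 3 to compound 4 (0.04 log units; that floor lies within the scatter), an at least 1.1-fold lower number from compound 2 to compound 4 (0.04 log units; that floor lies within the scatter) and an at least 1.1-fold lower number from compound 1 to compound 4 (0.04 log units; that floor lies within the scatter), so none shows a change beyond the scatter. The steps among compound 1, compound 2 and compound 3 cannot be read, and those three stay at a limit: the limit of > 60000 nM in this assay, at which 3 of the 4 values shown sit.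

From the compounds shown here alone, the true size of each step remains open. Also open, going by these compounds, is whether an amine or a carboxylic acid in place of naphthalen-2-yl on the carbonyl carbon would give a readable number.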